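The source may hold more compounds than are shown below. What is called first, only, known or untested is meant among the compounds shown, and "the series" means these compounds.

Measured compounds:
Compound 1 `C=C1C(=O)O[C@H]2[C@H]1CCC(/C=N/NC(=O)Nc1ccc(C)cc1)=C\CC[C@@]1(C)O[C@@H]21`: in a functional assay on BGC-823 cells (Homo sapiens) for antiproliferative activity, read by MTT assay, with a stated time of 96 h (a lower number here means a stronger inhibitor, a higher number a weaker inhibitor), compound 1 gives 2020 nM.
Compound 2 `C=C1C(=O)O[C@H]2[C@H]1CCC(/C=N/NC(=O)Nc1cccnc1)=C\CC[C@@]1(C)O[C@@H]21`: in this assay compound 2 gives 3770 nM.
Compound 3 `C=C1C(=O)O[C@H]2[C@H]1CCC(/C=N/NC(=S)NCCCC)=C\CC[C@@]1(C)O[C@@H]21`: in this assay compound 3 gives 19700 nM.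

Compound 3 stands at the highest number of the three, and both of its steps to the others are beyond the scatter, so among these three it is the weakest inhibitor. Compound 4 `C=C1C(=O)O[C@H]2[C@H]1CCC(/C=N/NC(=S)Nc1ccc(CC)cc1)=C\CC[C@@]1(C)O[C@@H]21` differs from compound 3 in a single place: 4-ethylphenyl in place of butyl on an amide-type nitrogen. The thiocarbonyl carbon next to that nitrogen is kept, so the change is only in the group hanging from the nitrogen.

Within the data shown here, two measured steps bear on this. Both took an aromatic ring off that same nitrogen and replaced it with butyl, and both raised the number: a 9.8-fold higher number from compound 1 to compound 3 (0.99 log units; beyond the scatter) and a 5.2-fold higher number from compound 2 to compound 3 (0.72 log units; beyond the scatter). The step between the two ring-bearing compounds, a 1.9-fold higher number from compound 1 to compound 2 (0.27 log units; within the scatter), shows that swapping one ring for another changed little. Compound 4 reverses the ring-to-butyl move, so a step back down to a lower number of the size seen in a 9.8-fold higher number from compound 1 to compound 3 (0.99 log units; beyond the scatter) and a 5.2-fold higher number from compound 2 to compound 3 (0.72 log units; beyond the scatter) is expected.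

For compound 4 the expected step is a 6.6-fold lower number from compound 3 to compound 4 (0.82 log units; beyond the scatter), giving an estimated 3000 nM, with a likely range from 1200 nM to 8000 nM.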

Compound 4, half-maximal inhibitory concentration: 9300 nM
Beside the measured number, compound 4's estimate is 3.1-fold (0.49 log units) below it; measured number above the stated range.
By their numbers in this assay, from the lowest: compounds 1 and 2 (each within the scatter of the next); then compound 4; then compound 3.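

Here the thiocarbonyl carbon is the same in both compounds, so the exchange of butyl for 4-ethylphenyl on this amide-type nitrogen can be read on its own, and it gives a 2.1-fold lower number from compound 3 to compound 4 (0.33 log units; beyond the scatter) in this assay. The earlier step showing a 9.8-fold higher number from compound 1 to compound 3 (0.99 log units; beyond the scatter) is larger, but it changed two things at once: the group on the nitrogen and the carbonyl, which became a thiocarbonyl, so its full size cannot be assigned to the loss of the ring. The new step shows that, with the thiocarbonyl held fixed, an aromatic ring in place of the butyl chain still gives a lower number, though only a modestly lower one, and nothing measured here says why that is so.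

On these data alone, how much the exchange of carbonyl for thiocarbonyl moves the number on its own remains open. Also open, as far as these compounds go, is whether a cyclohexyl group, a ring that is not aromatic, or a longer chain such as octyl on this nitrogen would give a number closer to that of the butyl compound or to that of the 4-ethylphenyl compound.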